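This account rests on a few compounds, and the source may have more. Where it says the series, first, only, none or still open, it means among the compounds named here.

Of the compounds shown here, two carry a number so far. Compound 1 `C[C@H](NC(=O)c1cc(C(F)(F)F)nn1C)c1nc(-c2cccnc2)no1` gives 11800 nM in an assay on T-REx-293 cells for inhibition of potassium channel subfamily T member 1 (Homo sapiens), read by patch clamp; on this read-out lower numbers stand for stronger inhibition and higher numbers for weaker inhibition. Compound 2 `COc1cc(-c2noc([C@H](C)NC(=O)c3cc(C(F)(F)F)nn3C)n2)ccn1` gives 27 nM in this assay. Among the measured compounds shown here, the single measured step between them, a 440-fold lower number from compound 1 to compound 2 (2.64 log units; beyond the scatter), arises from the exchange of the pyridyl group. For the measured compounds named here, compound 2 therefore stands at the lowest of the two numbers, with compound 1 as its only neighbour far above it.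

Compound 3 `C[C@H](NC(=O)c1cc(C(F)(F)F)nn1C)c1nc(-c2ccnc(C3CC3)c2)no1` differs from compound 2 by cyclopropyl in place of methoxy on an aromatic carbon. Going by the values given here, no measured step exchanges a methoxy for a cyclopropyl, so no direct precedent exists for this change. Among the compounds with values here, the one step that touches the same ring, a 440-fold lower number from compound 1 to compound 2 (2.64 log units; beyond the scatter), shows that this part of the molecule can move the number a great deal, but it concerns a different exchange and gives no direction for the present one. With the ring nitrogen kept and only the group next to it replaced, compound 3 is expected to stay near compound 2, most likely a little weaker, a step of about a 2.2-fold higher number from compound 2 to compound 3 (0.35 log units; beyond the scatter). The estimate for compound 3 in this assay is 60 nM, within 12 nM to 300 nM.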

Compound 3, half-maximal inhibitory concentration: 16 nM
Compound 3: middle estimate off by 3.8-fold (0.57 log units), on the high side; measured number inside the range.
By their numbers in this assay, from the lowest: compounds 3 and 2 (each within the scatter of the next); then compound 1.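

At this position, on the aromatic carbon next to the ring nitrogen, methoxy and cyclopropyl cannot be told apart in this assay, with a 1.7-fold lower number from compound 2 to compound 3 (0.23 log units; within the scatter) separating them. Methoxy, with its oxygen and its hydrogen-bond acceptor, can therefore leave and a three-membered ring of carbon only can enter without a shift beyond the scatter. The low number of compound 2 is thus not tied to methoxy: a 740-fold lower number from compound 1 to compound 3 (2.87 log units; beyond the scatter) is also a large step, so the 2-cyclopropylpyridin-4-yl group, like the 2-methoxypyridin-4-yl group, stands far from pyridin-3-yl on this read-out. No further measurement bears on this result.

The steps from compound 1 exchange pyridin-3-yl for a whole substituted pyridinyl group, so the shares of the ring's arrangement and of the added group cannot be separated with these compounds. As far as these compounds go, how an amine, a carboxylic acid, a longer alkyl chain or a plain hydrogen on the same carbon would read against methoxy and cyclopropyl remains open.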